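The source may hold more compounds than are shown below. What is called first, only, known or untested is meant among the compounds shown, and "the series" means these compounds.

Working notes on the series. Within the data shown here, compound 3 `C=CC(=O)Nc1cccc(Oc2nc(Nc3cccc(C#N)c3)nc3ccsc23)c1` gives 6390 nM in a functional assay on HeLa cells (Homo sapiens) for inhibition, read by MTT assay, with a stated time of 72 h (a higher number here means a weaker inhibitor, a lower number a stronger inhibitor), the lowest of the two numbers so far; compound 1 `C=CC(=O)Nc1cccc(Oc2nc(Nc3cccc(OC)c3)nc3ccsc23)c1` gives 16400 nM, and the only measured step, a 2.6-fold lower number from compound 1 to compound 3 (0.41 log units; beyond the scatter), concerns the aromatic substituent. Compound 2 `COc1ccc(Nc2nc(Oc3cccc(NC(=O)/C=C/C(C)C)c3)c3sccc3n2)cn1` returns only a limit, > 50000 nM, see (the limit of > 50000 nM in this assay, at which 1 of the 3 values shown sits). Compound 4 `CC/C=C/C(=O)Nc1cccc(Oc2nc(Nc3cccc(C#N)c3)nc3ccsc23)c1` differs from compound 3 by but-1-en-1-yl in place of vinyl on a carbonyl carbon. Among the measured compounds shown here, no measured step touches the carbonyl substituent, so the expectation rests on compound 2, whose extended alkenyl amide gave a limit rather than a number. A weaker number is therefore expected for compound 4, by roughly a 3.1-fold higher number from compound 3 to compound 4 (0.50 log units; beyond the scatter), with a fair chance of another limit. Compound 4 is estimated at 20000 nM, range 6000 nM to 60000 nM.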

Compound 4, half-maximal inhibitory concentration: 69400 nM
Compound 4: the middle estimate sits 3.5-fold (0.54 log units) below what was measured, and the stated range ends below it.
By their numbers in this assay, from the lowest: compound 3; then compound 1; then compound 4.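

Among these compounds, the step at the carbonyl carbon, an 11-fold higher number from compound 3 to compound 4 (1.04 log units; beyond the scatter), is the first measured change at this position, and it is large, whereas the change at the aromatic substituent, a 2.6-fold lower number from compound 1 to compound 3 (0.41 log units; beyond the scatter), is modest. Adding to the vinyl group to give but-1-en-1-yl thus costs far more in this assay than exchanging methoxy for cyano. Compound 2 also carries a longer alkenyl amide but differs in more than one place, and its value remains a limit: the limit of > 50000 nM in this assay, at which 1 of the 4 values shown sits.

Going by these compounds, whether this step tracks chain length or the double bond remains open. An ethyl group or a dimethylamino-substituted but-1-en-1-yl chain on the carbonyl carbon would help separate these readings.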